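The compounds below may be only part of what the source reports. "The series", "measured", "known", "first", "only" and "open" are said of these compounds alone.

In an assay on COS-7 cells for inhibition of patatin-like phospholipase domain-containing protein 2 (Mus musculus) (on this read-out lower numbers stand for stronger inhibition and higher numbers for weaker inhibition), compound 1, `CCOC(=O)c1cccc(-c2ccc(CN3CCCC3)cc2)c1`, gives > 200000 nM, and this is a limit of the assay rather than a number. Compound 2, `CCOC(=O)c1cccc(-c2ccc3[nH]ccc3c2)c1`, gives 60000 nM in this assay. Compound 3, `CCOc1ccc(-c2cccc(S(=O)(=O)N(C)C)c2)cc1`, gives 110000 nM in this assay, a number that sits within the usual scatter of the value of compound 2, so the two cannot be told apart. Compound 4, `CCOc1ccc(-c2cccc(NC(C)=O)c2)cc1`, differs from compound 3 in a single place: acetamido in place of dimethylsulfamoyl on an aromatic carbon. For the measured compounds named here, no measured pair here shows this change, so nothing about its size is known from the data. The step from compound 3 to compound 4 in this assay is expected to be a 1.1-fold lower number from compound 3 to compound 4 (0.04 log units; within the scatter), no larger than the scatter in either direction. Compound 4 is therefore estimated at 100000 nM in this assay, between 30000 nM and 300000 nM.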

Compound 4, half-maximal inhibitory concentration: 200000 nM
Estimate against measurement, compound 4: 2.0-fold (0.30 log units) below, within the range that was stated.
By their numbers in this assay, from the lowest: compounds 2, 3 and 4 (each within the scatter of the next, the first and the last beyond it).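

For the compounds shown here, this is the first pair that differs in one place, and swapping dimethylsulfamoyl for acetamido on this aromatic carbon gives a 1.8-fold higher number from compound 3 to compound 4 (0.26 log units; within the scatter). The two groups therefore cannot be told apart in this assay, even though acetamido has fewer heavy atoms and carries a hydrogen-bond donor that dimethylsulfamoyl lacks. Compound 1 gives a limit and not a number, so these values lie close to the end of what the assay can report: the limit of > 200000 nM in this assay, at which 1 of the 4 values shown sits.

From the compounds shown here alone, whether any group at this position can give a clearly lower number remains open. A primary amine or a carboxylic acid on the same carbon would begin to test this.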